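A few compounds are considered here, and "the series" means these few. Any claim that something is new, unique, unknown or untested is made for them only; others in the source may bear on it.

In a functional assay on NCI-H460 cells (Homo sapiens) for inhibition, read by MTT assay, with a stated time of 72 h (a lower number here means a stronger inhibitor, a higher number a weaker inhibitor), compound 2 `COc1cc(NC(C)CCCNC(=O)NNC(=O)Nc2ccc(C(F)(F)F)cc2)c2ncccc2c1` gives 12000 nM and compound 3 `COc1cc(NC(C)CCCNC(=O)Nc2cccc(C(F)(F)F)c2)c2ncccc2c1` gives 21000 nM, and these two values lie within the usual scatter of each other. Compound 1 `COc1cc(NC(C)CCCNC(=O)NNC(=O)Nc2ccc(F)cc2)c2ncccc2c1` reports > 100000 nM as a limit and not a number. Compound 4 `COc1cc(NC(C)CCCNC(=O)NNC(=O)Nc2cccc(C(F)(F)F)c2)c2ncccc2c1` has the same atoms as compound 2, joined differently, with 3-(trifluoromethyl)phenyl in place of 4-(trifluoromethyl)phenyl on an amide-type nitrogen. The steps of an at least 8.3-fold lower number from compound 1 to compound 2 (0.92 log units; beyond the scatter) and an at least 4.7-fold lower number from compound 1 to compound 3 (0.67 log units; beyond the scatter) both start from that limit, and neither is this same change. Compound 3 at 21000 nM already carries 3-(trifluoromethyl)phenyl, so no step beyond the scatter is expected. In this assay the expected change is a 1.2-fold higher number from compound 2 to compound 4 (0.07 log units; within the scatter) in size, which stays within the scatter. Compound 4 is expected at 14000 nM (estimated range 6000 nM to 35000 nM).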

Compound 4, half-maximal inhibitory concentration: 20000 nM
The estimate for compound 4 lay 1.4-fold (0.15 log units) below the measured number, within the range that was stated.
By their numbers in this assay, from the lowest: compounds 2, 4 and 3 (each within the scatter of the next). At a limit, above all of these: compound 1.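

In this assay, 3-(trifluoromethyl)phenyl in place of 4-(trifluoromethyl)phenyl on the amide-type nitrogen gives a 1.7-fold higher number from compound 2 to compound 4 (0.22 log units; within the scatter), so this change in the trifluoromethyl group's place does not separate the two compounds. Replacing 4-fluorophenyl with 3-(trifluoromethyl)phenyl at the same nitrogen gives an at least 5.0-fold lower number from compound 1 to compound 4 (0.69 log units; beyond the scatter). The value of compound 1 is a limit and not a number: the limit of > 100000 nM in this assay, at which 1 of the 4 values shown sits.

Still open, going by these compounds, is whether a nitrile or a carboxylic acid in place of the trifluoromethyl group would shift the number beyond the scatter. The same question stands for a longer chain between the shared core and the urea-type end.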